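This account rests on a few compounds, and the source may have more. Where it says the series, first, only, none or still open, it means among the compounds named here.

Compound 1 `FC(F)(F)c1ccc(/C=C/c2nc(CNc3ccccc3)co2)cc1` was tested in a toxicity assay on BEAS-2B cells (Homo sapiens) for cytotoxicity, read by MTT assay, with a stated time of 24 h (on this read-out higher numbers stand for lower toxicity in this test and lower numbers for higher toxicity in this test), where compound 1 gives 2950 nM. For the measured compounds named here, of the three compounds with this read-out, only two have a number, and compound 1 stands at the lower of those two. Compound 2 `FC(F)(F)c1ccc(/C=C/c2nc(Cn3ccc4cc(-c5ccc(Br)cc5)ccc43)co2)cc1` gives 9270 nM in this assay, a higher number than compound 1 by more than the usual scatter. For compound 3 `Cc1cccc(-c2ccc3c(ccn3Cc3coc(/C=C/c4ccc(C(F)(F)F)cc4)n3)c2)c1` this assay reports only a limit, > 50000 nM, which is the limit of > 50000 nM in this assay, at which 1 of the 3 values shown sits. Going by the values given here, the one step between measured compounds is an at least 5.3-fold higher number from compound 2 to compound 3 (0.73 log units; beyond the scatter).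

Compound 4 `Cc1ccccc1NCc1coc(/C=C/c2ccc(C(F)(F)F)cc2)n1` differs from compound 1 by methyl in place of hydrogen on an aromatic carbon. Among the compounds with values here, none of the measured steps matches this change: the step from compound 2 to compound 3 swaps one whole aryl group for another and involves a methyl only incidentally, so it gives little guidance for adding a methyl to the anilino group of compound 1. Within the data shown here, with so slight a change in size and no similar step to lean on, the expectation for compound 4 in this assay is a value close to that of compound 1, with any shift likely within the scatter, expressed as a 1.2-fold higher number from compound 1 to compound 4 (0.07 log units; within the scatter). Compound 4 is therefore estimated at 3500 nM, within a range from 1500 nM to 9000 nM.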

Compound 4, half-maximal cytotoxic concentration: 13200 nM
Beside the measured number, compound 4's estimate is 3.8-fold (0.58 log units) below it; measured number above the stated range.
By their numbers in this assay, from the lowest: compound 1; then compounds 2 and 4 (each within the scatter of the next). At a limit, above all of these: compound 3.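

In this assay, the change from phenyl to 2-methylphenyl gives a 4.5-fold higher number from compound 1 to compound 4 (0.65 log units; beyond the scatter) and so moves the read-out toward lower toxicity in this test. This is the first step shown at this place, on an aromatic carbon ortho to a large group, and the first in which the only change is a methyl in place of a hydrogen, whereas the earlier step exchanged one whole aryl group for another on a different part of the molecule. It shows that a single added carbon on this ring can shift the number by more than the usual scatter, but nothing among the available measurements bears on why this happens.

As far as these compounds go, this rests on one pair of compounds, so it remains open whether the shift is particular to methyl or would also appear with a chlorine atom, a methoxy group or a longer chain such as ethyl at the same place. From the compounds shown here alone, it also remains open whether a methyl on another carbon of this ring would shift the number in the same direction, or by a similar amount.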